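The source may report more compounds than this note shows. Statements on the series, on what has been measured and on what is new or still open speak of the compounds shown alone.

Measured compounds:
- compound 1, `Cc1nn(-c2ccccc2)c2nc(C(=O)N3NC(=O)/C(=C/c4ccc(Cl)cc4)N=C3c3ccccc3)[nH]c(=O)c12`: 28.1 nM
- compound 2, `Cc1nn(-c2ccccc2)c2nc(C(=O)N3NC(=O)/C(=C/c4ccccc4)N=C3c3ccc(Cl)cc3)[nH]c(=O)c12`: 13.9 nM

For the measured compounds named here, in a functional assay on HCT-116 cells (Homo sapiens) for cytotoxicity, read by MTT assay, with a stated time of 48 h (on this read-out higher numbers stand for weaker inhibition and lower numbers for stronger inhibition), compound 2 gives 13.9 nM, the lower of the two numbers measured so far, and compound 1 gives 28.1 nM, a difference that lies beyond the usual scatter. Going by the values given here, the two differ in more than one place, so no single step between them is counted; only what their two values show is taken here.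

Compound 3, `Cc1nn(-c2ccccc2)c2nc(C(=O)N3NC(=O)/C(=C/c4ccc(Cl)cc4)N=C3c3ccc(Cl)cc3)[nH]c(=O)c12`, has not been measured in this assay. It differs from compound 2 by one change: chloro in place of hydrogen on an aromatic carbon. Among the compounds with values here, no measured pair carries this exact change, so its size is not known from the series. On what is shown, a small step is expected, downward if at all, and it may well stay within the scatter. Compound 3 is expected to give 12 nM, in the range 5 nM to 30 nM, corresponding to an expected step of a 1.2-fold lower number from compound 2 to compound 3 (0.06 log units; within the scatter).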

Compound 3, half-maximal inhibitory concentration: 15 nM
The estimate for compound 3 lay 1.3-fold (0.10 log units) below the measured number; the range from low to high includes it.
By their numbers in this assay, from the lowest: compounds 2, 3 and 1 (each within the scatter of the next, the first and the last beyond it).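

In this assay, phenyl to 4-chlorophenyl gives a 1.1-fold higher number from compound 2 to compound 3 (0.03 log units; within the scatter) at one place on the shared core and a 1.9-fold lower number from compound 1 to compound 3 (0.27 log units; within the scatter) at the other. The same change has therefore now been read at two places, and neither step leaves the scatter. Compound 3, which carries 4-chlorophenyl at both places, thus stands within the scatter of each compound with a single chloro, so this second chloro brings no measurable change in this assay.

No measurement on hand offers an explanation for these steps. Still open, as far as these compounds go, is whether a different group at this para position, such as methoxy, an amine or a carboxylic acid, would move the number beyond the scatter.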